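A few compounds are considered here, and "the series" means these few. Any claim that something is new, unique, unknown or untested is made for them only; others in the source may bear on it.

Measured in an ADME assay on PA-1 cells (Homo sapiens) for cytotoxicity, read by MTT assay, with a stated time of 72 h; on this read-out lower numbers stand for stronger inhibition and higher numbers for weaker inhibition:
Compound 1 `COC(=O)c1cc(C2=C(c3cc(OC)c(OC)c(OC)c3)C(=O)CC2O[SiH2]C(C)(C)C)ccc1OC`: > 100 ug/mL (a limit)
Compound 2 `COc1cc(C2=C(c3ccc(SC)cc3)CC(O[SiH2]C(C)(C)C)C2=O)cc(OC)c1OC`: < 1 ug/mL (a limit)
Compound 3 `COc1ccc(C2=C(c3cc(OC)c(OC)c(OC)c3)C(=O)C(OC(C)=O)C2)cc1Cl`: > 100 ug/mL (a limit)

Compound 1 stands at > 100 ug/mL, which is a limit and not a number. It is one of the compounds in the limit of > 100 ug/mL in this assay, at which 2 of the 3 values shown sit, and compound 3 is the other. The opposite end is held by compound 2 alone, as the limit of < 1 ug/mL in this assay, at which 1 of the 3 values shown sits, records.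

Compound 4 `COc1ccc(C2=C(c3cc(OC)c(OC)c(OC)c3)C(=O)CC2O[SiH2]C(C)(C)C)cc1O` keeps the core of compound 1 and changes one group: hydroxy in place of methoxycarbonyl on an aromatic carbon. This puts hydroxy in place of methoxycarbonyl on an aromatic carbon, ortho to a methoxy group, turning 4-methoxy-3-(methoxycarbonyl)phenyl into 3-hydroxy-4-methoxyphenyl.

Going by the values given here, no measured pair isolates this change, and compound 1 offers no number to start from. Even so, a move toward stronger inhibition in this assay is expected, and the estimated size is an at least 33-fold lower number from compound 1 to compound 4 (1.52 log units; beyond the scatter). This expectation rests on compound 2, whose < 1 ug/mL is a limit and shows that the series can reach the low end. Compound 3 goes against any easy gain, with its > 100 ug/mL also a limit, so the expected range stays wide. For compound 4 the estimate is 3 ug/mL, with an expected range from 0.2 ug/mL to 100 ug/mL.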

Compound 4, half-maximal inhibitory concentration: 14 ug/mL
Beside the measured number, compound 4's estimate is 4.7-fold (0.67 log units) below it; the measured number falls inside the stated range.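

In this assay, putting hydroxy in place of methoxycarbonyl on this aromatic carbon, ortho to a methoxy group, gives an at least 7.1-fold lower number from compound 1 to compound 4 (0.85 log units; beyond the scatter), which shows that this position bears on the read-out while the rest of the core stays unchanged. Compound 4, at 14 ug/mL, carries the first value shown that is a number and not a limit, so the series now has a measured point against which further changes at this position can be read. The size of the step has only a floor, because compound 1 sits at a limit and not at a number: the limit of > 100 ug/mL in this assay, at which 2 of the 4 values shown sit.

The compounds shown leave open whether the lower number goes with the arrival of hydroxy or with the loss of methoxycarbonyl, and how an amine or a carboxylic acid on the same aromatic carbon would read in this assay. They also leave open how much of the distance to the limit held by compound 2 could be covered by changes at this position alone, as compound 2 differs from compound 4 in more than one place.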